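Methylating the Phenol of a Weakly Active Oxindole

The source may report more compounds than this note shows. Statements on the series, on what has been measured and on what is new or still open speak of the compounds shown alone.

Compound 1, `COc1cc2c(/C=C3/C(=O)Nc4ccc(O)cc43)c(Cl)n(Cc3cc(OC)c(OC)c(OC)c3)c2cc1C`: 32400 nM in a functional assay on NSCLC cells (Homo sapiens) for cytotoxicity, with a stated time of 48 h; on this read-out higher numbers stand for weaker inhibition of growth and lower numbers for stronger inhibition of growth
Compound 2, `COc1c(/C=C2/C(=O)Nc3ccccc32)c2ccccc2n1-c1ccccc1`: 8320 nM in this assay

Going by the values given here, of the two numbers measured so far, compound 1 stands highest: compound 2 gives the lower value, and the gap between the two lies beyond the usual scatter, so compound 2 inhibits growth more strongly. The two compounds differ in several places at once, so these values show only where each stands and not what any single change does.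

Compound 3, `COc1ccc2c(c1)/C(=C\c1c(Cl)n(Cc3cc(OC)c(OC)c(OC)c3)c3cc(C)c(OC)cc13)C(=O)N2`, differs from compound 1 in one place: methyl in place of hydrogen on an oxygen on an aromatic ring. Among the compounds with values here, no pair among the measured compounds shows this change on its own, so its effect has to be estimated from what is known of compound 1 alone. Given that compound 1 gives 32400 nM, the change is expected to move the number little, with no step beyond the scatter in either direction and a weakly active compound remaining weakly active.

Compound 3 is therefore expected to give about 30000 nM, within a range from 10000 nM to 90000 nM. This estimate corresponds to an expected step of a 1.1-fold lower number from compound 1 to compound 3 (0.03 log units; within the scatter), which would stay within the scatter of repeated measurements.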

Compound 3, concentration for total growth inhibition: 97700 nM
Compound 3: the middle estimate sits 3.3-fold (0.51 log units) below what was measured, and the stated range ends below it.
By their numbers in this assay, from the lowest: compound 2; then compound 1; then compound 3.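

Going by these compounds alone, the pair of compound 1 and compound 3 gives the first reading of a single change, and it shows that this position is not indifferent to substitution: going from hydroxy to methoxy on the aromatic ring brings a 3.0-fold higher number from compound 1 to compound 3 (0.48 log units; beyond the scatter) in this assay, so the growth inhibition weakens. The earlier comparison of compound 1 with compound 2 could not show this, since those two differ in several places at once, whereas here only the methyl on the oxygen separates the compounds and the step lies beyond the usual scatter, though it remains modest. No measurement at hand says what lies behind this step.

The compounds shown leave open how other groups in this place would compare with hydroxy and methoxy, for example an amine, a carboxylic acid, or a longer chain on the oxygen such as ethoxy. The step also rests on this one pair, so whether the same change gives a similar step on a different core, or with other groups around the shared core of compound 1, remains an open question.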